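Series notes: carbamoylmethyl in place of cinnamyl on the core

A few compounds are considered here, and "the series" means these few. Any claim that something is new, unique, unknown or untested is made for them only; others in the source may bear on it.

Three compounds of the shared core have numbers in a functional assay (B cells) with Mus musculus as the target; a lower number here means that less compound is needed, a higher number that more compound is needed for the effect. Compound 1 `Nc1nc(O)c2c(n1)n(C1OC(CO)[C@@H](O)[C@H]1O)c(=O)n2C/C=C/c1ccccc1` gives 103 uM in this assay. Compound 3 `C=CCSc1nc2c(O)nc(N)nc2n1C1OC(CO)[C@@H](O)[C@H]1O` gives 107 uM; its value and that of compound 1 lie within the scatter of each other. Compound 2 `C=CCn1c(=O)n([C@@H]2O[C@H](CO)[C@H]3OC(CCC)(CCC)O[C@H]32)c2nc(N)nc(O)c21` gives 4 uM, a number far lower than those of compound 1 and compound 3 and beyond the scatter, yet compound 2 differs from both at more than one place, so no single change can be read from it. Compound 1 thus stands with compound 3 at the high end of the numbers seen so far.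

Compound 4 `NC(=O)Cn1c(=O)n(C2OC(CO)[C@@H](O)[C@H]2O)c2nc(N)nc(O)c21` is the next compound for this assay. It differs from compound 1 in one place: carbamoyl in place of 2-phenylethenyl on a saturated chain carbon bound to an aromatic nitrogen. For the measured compounds named here, no measured pair shows this change alone, so nothing in the data fixes its size. A modest step upward in number is expected, a 1.5-fold higher number from compound 1 to compound 4 (0.16 log units; within the scatter), because compound 1 already sits at 103 uM and no measured neighbour supports a drop. Compound 4 is estimated at 150 uM, with a range from 40 uM to 600 uM.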

Compound 4, concentration for half-maximal effect: 190 uM
Estimate against measurement, compound 4: 1.3-fold (0.10 log units) below; low and high end bracket the measured number.
By their numbers in this assay, from the lowest: compound 2; then compounds 1, 3 and 4 (each within the scatter of the next).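

For the compounds shown here, on a saturated chain carbon bound to an aromatic nitrogen, carbamoyl in place of 2-phenylethenyl gives, in this assay, a 1.8-fold higher number from compound 1 to compound 4 (0.27 log units; within the scatter), the first step that can be read at a single place. The change from 3-phenylprop-2-en-1-yl to carbamoylmethyl removes the six-membered aromatic ring and brings in a hydrogen-bond donor and acceptor, yet it does not separate the two compounds beyond the scatter. Nothing measured here explains this outcome.

From the compounds shown here alone, whether a carboxylic acid, an amine or a longer chain at this position would move the number beyond the scatter remains open. Also open, going by these compounds, is whether the change from 2-phenylethenyl to carbamoyl keeps the same size when other parts of the shared core are altered.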